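Acid dissociation across the aryl substituent of the core

This account rests on a few compounds, and the source may have more. Where it says the series, first, only, none or still open, it means among the compounds named here.

Compound 1 `COc1ccc(Oc2ccc3c(NCCCNCc4cc(F)ccc4OC)ccnc3c2)cc1`, compound 2 `COc1ccc(F)cc1CNCCCNc1ccnc2cc(Cc3ccc(C#N)cc3)ccc12` and compound 3 `COc1ccc(F)cc1CNCCCNc1ccnc2cc(-c3ccc(C(F)(F)F)cc3)ccc12` share one core and differ only in the group on one aromatic carbon. In a physicochemical assay for acid dissociation, compound 1 gives 9.28, compound 2 gives 9.47 and compound 3 gives 9.47. Compound 3 stands level with compound 2 at the digits shown, and its furthest neighbour is compound 1. The three steps at this position are a number 0.19 log units higher from compound 1 to compound 2 (within the scatter), a number 0.19 log units higher from compound 1 to compound 3 (within the scatter) and no change at the digits printed from compound 2 to compound 3 (within the scatter). Compound 4 `COc1ccc(F)cc1CNCCCNc1ccnc2cc(Oc3cccc(N(C)C)c3)ccc12` is not yet measured; against compound 3 it shows (3-(dimethylamino)phenoxy in place of 4-(trifluoromethyl)phenyl on an aromatic carbon). Since all three steps at this position stay within the scatter, no step beyond the scatter is expected for compound 4 in this assay. Compound 4 is therefore estimated at 9.45, between 9.15 and 9.75, an expected step of a number 0.02 log units lower from compound 3 to compound 4 (within the scatter).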

Compound 4, acid dissociation constant: 9.28
For compound 4 the middle estimate is 0.17 log units above the measured one, and the stated range covers the measured number.
By their numbers in this assay, from the lowest: compounds 1, 4, 2 and 3 (each within the scatter of the next).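

In this assay, a dimethylamino group on the aryl ring, new to this series, still leaves the read-out within the scatter: a number 0.19 log units lower from compound 3 to compound 4 (within the scatter) and a number 0.19 log units lower from compound 2 to compound 4 (within the scatter). With the aryl ether linkage kept, 3-(dimethylamino)phenyl in place of 4-methoxyphenyl on the oxygen gives no change at the digits printed from compound 1 to compound 4 (within the scatter), so this exchange registers no difference at the digits printed. Nothing available bears on the reason for these results.

Still open, going by these compounds, is whether a carboxylic acid or a primary amine on this aryl ring, or a longer chain linking it to the shared core, would give a step beyond the scatter.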